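Two limits and one open question

The source may report more compounds than this note shows. Statements on the series, on what has been measured and on what is new or still open speak of the compounds shown alone.

Values in an ADME assay on L02 cells (Homo sapiens) for cytotoxicity, read by MTT assay; on this read-out higher numbers stand for weaker inhibition and lower numbers for stronger inhibition:
Compound 1 `COc1ccc(/C=C/C(=O)c2ccc(OC)c3c2OC(C)(C)C=C3)cc1OC(=O)C(C)C`: > 10000 nM (a limit)
Compound 2 `COc1ccc(/C=C/C(=O)c2ccc(OC)c3c2OC(C)(C)C=C3)cc1OC(=O)c1ccco1`: > 10000 nM (a limit)
Compound 3 `COc1ccc(/C=C/C(=O)c2ccc(OC)c3c2OC(C)(C)C=C3)cc1OS(=O)(=O)Cc1ccccc1`: not yet measured

Compound 2 has no exact number, only > 10000 nM, which is a limit of the assay. Within the data shown here, the same holds across the series so far: the limit of > 10000 nM in this assay, at which 2 of the 2 values shown sit.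

The next change is benzylsulfonyl in place of (furan-2-yl)carbonyl on an oxygen on an aromatic ring. Among the measured compounds shown here, the one measured step that bears on it is a step that the two limits leave unreadable from compound 1 to compound 2, so it offers no size to carry over. No step beyond the scatter can therefore be predicted in this assay, and no direction can be given with confidence.

Compound 3 is expected to remain weak, because compound 2 gives > 10000 nM. The estimated step is a step that the limit leaves unreadable from compound 2 to compound 3. For compound 3 the estimated value is 20000 nM, with an expected range of 10000 nM to 50000 nM.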

Compound 3, half-maximal inhibitory concentration: > 10000 nM
Compound 3 was reported as a limit (the forecaster's own chance of this, stated with the estimate: 75%); the middle value does not contradict the limit.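

Among these compounds, no step among compound 1, compound 2 and compound 3 can be read in this assay, because all their values are limits: the limit of > 10000 nM in this assay, at which 3 of the 3 values shown sit. The compounds shown leave open what exact value each one has and whether the three differ at all.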